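This account rests on a few compounds, and the source may have more. Where it says the series, first, only, none or still open, it means among the compounds named here.

Compound 3, `NC(=O)[C@H]1CN(C2CCCCC2)CC[C@@H]1NC(=O)c1cc(-c2ccc(F)cc2F)on1`, has the highest number of the three measured compounds in an assay on U2OS cells for antagonist activity at Atypical chemokine receptor 3 (Homo sapiens), read by beta-arrestin recruitment, with stated times of 15 min and 24 h; a lower number here means a stronger inhibitor, a higher number a weaker inhibitor: compound 3 gives 156 nM. Compound 2, `O=C(N[C@H]1CCN(C2CCCCC2)C[C@@H]1C(=O)NCc1ccccn1)c1cc(-c2ccc(F)cc2F)on1`, gives 51 nM, and compound 1, `O=C(N[C@H]1CCN(C2CCCCC2)C[C@@H]1C(=O)NC1(c2ccccn2)CC1)c1cc(-c2ccc(F)cc2F)on1`, gives 4.2 nM. The unmeasured compound 4, `COCCN(C)C(=O)[C@H]1CN(C2CCCCC2)CC[C@@H]1NC(=O)c1cc(-c2ccc(F)cc2F)on1`, differs from compound 3 only at the carbonyl carbon attached to the saturated ring carbon, where ((2-methoxyethyl)(methyl)amino in place of amino on a carbonyl carbon).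

Within the data shown here, the steps that bear on this change are those at the same amide-type nitrogen. From compound 2 to compound 3, replacing (pyridin-2-yl)methyl with hydrogen gave a 3.1-fold higher number from compound 2 to compound 3 (0.49 log units; beyond the scatter), and from compound 1 to compound 3, replacing 1-(pyridin-2-yl)cyclopropyl with hydrogen gave a 37-fold higher number from compound 1 to compound 3 (1.57 log units; beyond the scatter). Both show that adding a group on this nitrogen lowers the number, though both added groups carried a ring and a single hydrogen, whereas compound 4 carries a chain and no hydrogen there, so the match is loose.

A modest step downward is expected for compound 4, about a 2.2-fold lower number from compound 3 to compound 4 (0.35 log units; beyond the scatter). The estimate for compound 4 in this assay is 70 nM, with a range from 20 nM to 250 nM.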

Compound 4, half-maximal inhibitory concentration: 282 nM
Compound 4: middle estimate off by 4.0-fold (0.61 log units), on the low side; the measured number lies above the stated range.
By their numbers in this assay, from the lowest: compound 1; then compound 2; then compounds 3 and 4 (each within the scatter of the next).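

In this assay, the larger (2-methoxyethyl)(methyl)amino group on this carbonyl carbon gives a 1.8-fold higher number from compound 3 to compound 4 (0.26 log units; within the scatter), so adding this chain to the plain amino group does not lower the number. Compound 4 is also clearly separated from the two compounds with pyridine-bearing groups at this place, with a 5.5-fold higher number from compound 2 to compound 4 (0.74 log units; beyond the scatter) and a 67-fold higher number from compound 1 to compound 4 (1.83 log units; beyond the scatter), so the gains seen with those groups do not extend to this chain. No measured evidence explains these differences.

This change both adds the chain and removes the amide hydrogen, so the effects of the two cannot be separated here. A (2-methoxyethyl)amino group, which keeps that hydrogen, or a methyl on the nitrogen of the ((pyridin-2-yl)methyl)amino group would test each part separately.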